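A few compounds are considered here, and "the series" means these few. Any claim that something is new, unique, unknown or untested is made for them only; others in the source may bear on it.

Compound 1, `c1ccc(C(/N=C2\CCCCCN2)C2CCCCC2)cc1`, is the lower of the two measured compounds: in a functional assay on the whole organism (plasma, strain Sprague-Dawley) with Rattus norvegicus as the target, with a stated time of 2 h, at a dose of 100 mg/kg by the oral route (a higher number here means a stronger effect of the compound at the dose given, a lower number a weaker effect), compound 1 gives 0%, while compound 2, `c1csc(C(/N=C2\CCCCCCN2)C2CC2)c1`, gives 50% in this assay, a gap beyond the usual scatter. Compound 3, `c1ccc(C(/N=C2\CCCCCN2)c2ccco2)cc1`, is not yet measured; it differs from compound 1 by furan-2-yl in place of cyclohexyl on a saturated chain carbon bound to an aromatic carbon and a double-bonded nitrogen. Within the data shown here, no measured pair isolates this change, so its effect is unknown. A moderate rise is expected, a number 20 percentage points higher from compound 1 to compound 3 (beyond the scatter), though a step within the scatter is also plausible. Compound 3 is estimated at 20% in this assay, with a range from 0% to 50%.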

Compound 3, a percentage reported as inhibition, in the whole organism at one dose (the size of the read-out at that dose, not a potency): 52%
For compound 3 the middle estimate is 32 percentage points below the measured one; the measured number lies above the stated range.
By their numbers in this assay, from the lowest: compound 1; then compounds 2 and 3 (each within the scatter of the next).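

With the rest of the core held fixed, furan-2-yl in place of cyclohexyl on a saturated chain carbon bound to an aromatic carbon and a double-bonded nitrogen gives a number 52 percentage points higher from compound 1 to compound 3 (beyond the scatter) in this assay. Among these compounds, this is the first single-place step, and it shows that the read-out depends strongly on the group at this position. No supporting data on hand bear on the reason for the step.

On these data alone, whether pyridin-2-yl or an n-butyl chain at this position would keep the read-out remains open. A single-dose read-out also leaves potency undefined.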